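Anilino to methylamino on the shared core

This account rests on a few compounds, and the source may have more. Where it says the series, first, only, none or still open, it means among the compounds named here.

Measured so far in a functional assay on SK-OV-3 cells (Homo sapiens) for cytotoxicity, read by MTT assay, with a stated time of 3 days; a higher number here means a weaker inhibitor, a lower number a stronger inhibitor:
- compound 1 `N#Cc1c(NN)nc(SCc2nc3ccccc3[nH]2)nc1-c1ccccc1`: 2.7 nM
- compound 2 `N#Cc1c(Nc2ccccc2)nc(SCc2nc3ccccc3[nH]2)nc1-c1ccccc1`: 4.46 nM

Among the measured compounds shown here, only these two values are available, and compound 2, at 4.46 nM, cannot be separated from its sole neighbour, as the two lie within the scatter of each other. The next compound to consider is compound 3 `CNc1nc(SCc2nc3ccccc3[nH]2)nc(-c2ccccc2)c1C#N`. It differs from compound 2 as follows: methyl in place of phenyl on a nitrogen on an aromatic ring. In words, this is methyl in place of phenyl on a nitrogen on an aromatic ring, or anilino to methylamino.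

For the measured compounds named here, one measured step bears on this change, since it alters the group in the same place. That step, a 1.7-fold higher number from compound 1 to compound 2 (0.22 log units; within the scatter), put phenyl in place of amino on a nitrogen on an aromatic ring and stayed within the scatter. Going by the values given here, no measured compound carries methyl in this place, so the evidence is indirect and thin. On that single step, no shift beyond the scatter is expected in this assay, and no direction can be favoured with confidence. The expected step is a 1.3-fold lower number from compound 2 to compound 3 (0.11 log units; within the scatter). For compound 3 the estimated value is 3.5 nM, with an expected range of 1.2 nM to 10 nM.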

Compound 3, half-maximal inhibitory concentration: 3 nM
The estimate for compound 3 lay 1.2-fold (0.07 log units) above the measured number, within the range that was stated.
By their numbers in this assay, from the lowest: compounds 1, 3 and 2 (each within the scatter of the next).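

In this assay the change from anilino to methylamino gives a 1.5-fold lower number from compound 2 to compound 3 (0.17 log units; within the scatter) and the replacement of amino by methyl on the same nitrogen gives a 1.1-fold higher number from compound 1 to compound 3 (0.05 log units; within the scatter) so neither step separates the compounds. With the earlier step, this position now has three groups side by side, and compounds 1, 2 and 3 cannot be put in any order, even though a single methyl carbon and a six-carbon aromatic ring differ widely in size. Removing the phenyl ring from this nitrogen therefore leaves the number within the scatter in this series, though no measurement shown here offers an account of that reading.

The compounds shown leave open whether a longer alkyl chain, a benzyl group or a chain ending in a carboxylic acid on this nitrogen would move the number beyond the scatter, since all three groups seen so far give values within the scatter of each other. From the compounds shown here alone, the contribution of the nitrile, the phenyl on the core and the thioether side chain also remains open, as all three compounds share them.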